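Working notes on compound 4 against three measured analogues

The source may report more compounds than this note shows. Statements on the series, on what has been measured and on what is new or still open speak of the compounds shown alone.

Of the compounds shown here, three have numbers so far. Compound 1 `CC(=O)OCc1ccc2oc(=O)c(C(=O)Sc3cccc(Br)c3)cc2c1` in a functional assay on HT-1080 cells (Homo sapiens), read by transwell migration, with a stated time of 24 h, tested at 1 uM (a higher number here means a weaker effect of the compound at the concentration tested, a lower number a stronger effect), gives 70.9%. Compound 2 `CCCCC(=O)OCc1ccc2oc(=O)c(C(=O)Oc3cccc(Br)c3)cc2c1` gives 63.3% in this assay, and compound 3 `O=C(Oc1cccc(I)c1)c1cc2cc([N+](=O)[O-])ccc2oc1=O` gives 63.6% in this assay. Compound 2 carries the lowest of the three numbers, but its gap to compound 3 and its gap to compound 1 both lie within the usual scatter, so no order among the three can be drawn and none of them is called more or less active than another.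

Compound 4 `CC(=O)NCc1ccc2oc(=O)c(C(=O)Oc3cccc(Br)c3)cc2c1` has not been measured in this assay. It differs from compound 2 in one place: acetamido in place of (butylcarbonyl)oxy on a saturated chain carbon bound to an aromatic carbon. Within the data shown here, no pair of measured compounds differs in a single place, so the size of this step has no precedent. The percentage read at one concentration moved little across the three analogues despite the differences in the groups they carry. The step of a number 1.7 percentage points higher from compound 2 to compound 4 (within the scatter) in this assay is expected to stay within the scatter, with no clear direction. For compound 4 the estimate in this assay is 65%, with a range from 50% to 80%.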

Compound 4, a percentage reported as activity, at one concentration (the size of the read-out at that concentration, not a potency): 36.9%
The estimate for compound 4 lay 28.1 percentage points above the measured number; measured number outside the range, below it.
By their numbers in this assay, from the lowest: compound 4; then compounds 2, 3 and 1 (each within the scatter of the next).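

Among these compounds, the step of a number 26.4 percentage points lower from compound 2 to compound 4 (beyond the scatter) in this assay is the first single-place change with a size beyond the scatter, and it shows that the read-out at this concentration responds to what sits on this saturated chain carbon bound to an aromatic carbon. Going from ((butylcarbonyl)oxy)methyl to acetamidomethyl, with the rest of the structure unchanged, gives a stronger effect, but the change alters several things at once: the heavy-atom count of the group falls from 7 to 4, nitrogen replaces an oxygen, and a hydrogen-bond donor enters where there was none. Nothing on hand indicates which of these features, if any, accounts for the step.

The compounds shown do not separate the amide link from the length of the chain, so a butanamido group on the same carbon would be the direct test of chain length, and an acetoxy group paired with the same ester would test the link. On these data alone, how a free amine or a carboxylic acid at this place would read also remains open, as does whether the step carries over to other groups on the shared core.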